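A few compounds are considered here, and "the series" means these few. Any claim that something is new, unique, unknown or untested is made for them only; others in the source may bear on it.

Compound 1 `O=C(/C=C/c1ccc(Cl)cc1)Nc1nc2ccccc2s1`: 367 umol/kg
Compound 2 `O=C(/C=C/c1ccc(O)cc1)Nc1nc2ccccc2s1`: 517 umol/kg
Compound 3 `O=C(/C=C/c1ccccc1)Nc1nc2ccc([N+](=O)[O-])cc2s1`: 485 umol/kg

In a functional assay on the whole organism (Hindlimb, strain albino) with Mus musculus as the target, in the maximal electroshock model, with a stated time of 0.5 h (a lower number here means that less compound is needed, a higher number that more compound is needed for the effect), compound 3 gives 485 umol/kg and sits in the middle of the three numbers, within the scatter of both compound 1 and compound 2. The three values therefore show no real order.

Next comes compound 4 `O=C(/C=C/c1ccccc1)Nc1nc2ccccc2s1`, which differs from compound 3 as follows: hydrogen in place of nitro on an aromatic carbon. This is hydrogen in place of nitro on an aromatic carbon. Going by the values given here, no measured step covers this exchange. Among the compounds with values here, the only measured step, a 1.4-fold higher number from compound 1 to compound 2 (0.15 log units; within the scatter), is a different exchange, hydroxy in place of chloro on an aromatic carbon, and it gives only weak guidance. Compound 1 and compound 2 carry no nitro, yet their values lie within the scatter of the value of compound 3. No step beyond the scatter is expected in this assay, in either direction. The expected change is a 1.1-fold lower number from compound 3 to compound 4 (0.03 log units; within the scatter), which stays within the scatter. For compound 4 the estimate is 450 umol/kg, with an expected range from 240 umol/kg to 850 umol/kg.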

Compound 4, dose for half-maximal effect: 646 umol/kg
Estimate against measurement, compound 4: 1.4-fold (0.16 log units) below, and the stated range covers the measured number.
By their numbers in this assay, from the lowest: compounds 1, 3, 2 and 4 (each within the scatter of the next).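

In this assay, going by these compounds alone, hydrogen in place of nitro on an aromatic carbon of the six-membered aromatic ring of carbon only, part of a fused or bridged system of two rings, gives a 1.3-fold higher number from compound 3 to compound 4 (0.12 log units; within the scatter) and so stays inside the scatter, which the earlier compounds could only suggest for this place. Within the data shown here, compound 4 also provides the first hydrogen comparison for the substituent on the other aromatic ring: a 1.2-fold higher number from compound 2 to compound 4 (0.10 log units; within the scatter) for hydroxy and a 1.8-fold higher number from compound 1 to compound 4 (0.25 log units; within the scatter) for chloro, neither of which leaves the scatter. No measurement here offers an explanation for these small steps.

On these data alone, it remains open whether an amine or a carboxylic acid at either place would give a step beyond the scatter. Also open, as far as these compounds go, is whether a longer chain there, or chloro or hydroxy on the fused system, would do so.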